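The compounds below may be only part of what the source reports. "The series", "measured", "known", "first", "only" and "open" are said of these compounds alone.

Three compounds have been measured:

compound 1, `CCC1=C(O)c2c(oc(-c3ccc(C(C)C)cc3)cc2=O)C(CC)(CC)C1=O`: 8.13 uM
compound 2, `CCC1=C(O)c2c(oc(-c3ccc(O)cc3)cc2=O)C(CC)(CC)C1=O`: 20.6 uM
compound 3, `CCC1=C(O)c2c(oc(-c3ccc(F)cc3)cc2=O)C(CC)(CC)C1=O`: 33 uM

In a functional assay on KB cells (Homo sapiens) for antiproliferative activity, read by sulforhodamine B assay, with a stated time of 3 days (on this read-out lower numbers stand for an effect already at smaller amounts and higher numbers for an effect only at larger amounts of compound), compound 1 stands lowest of the three numbers. The step of a 2.5-fold higher number from compound 1 to compound 2 (0.40 log units; beyond the scatter) and the step of a 4.1-fold higher number from compound 1 to compound 3 (0.61 log units; beyond the scatter) both move upward when the isopropyl group is exchanged, and the step of a 1.6-fold higher number from compound 2 to compound 3 (0.20 log units; within the scatter) separates the two exchanged compounds only slightly.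

Compound 4, `CCC1=C(O)c2c(oc(-c3ccc(OC)c(Cl)c3)cc2=O)C(CC)(CC)C1=O`, differs from compound 1 by 3-chloro-4-methoxyphenyl in place of 4-isopropylphenyl on an aromatic carbon. Within the data shown here, no measured step carries this exact change; the two steps away from the isopropyl group, both modest rises, are the nearest guides. A modest rise, or none beyond the scatter, is therefore expected. Compound 4 is estimated at 15 uM, within 6 uM to 40 uM. The expected step is a 1.8-fold higher number from compound 1 to compound 4 (0.27 log units; within the scatter).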

Compound 4, concentration for half-maximal effect: 24.9 uM
For compound 4 the middle estimate is 1.7-fold (0.22 log units) below the measured one; the range from low to high includes it.
By their numbers in this assay, from the lowest: compound 1; then compounds 2, 4 and 3 (each within the scatter of the next).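

In this assay, 3-chloro-4-methoxyphenyl in place of 4-isopropylphenyl gives another rise beyond the scatter (a 3.1-fold higher number from compound 1 to compound 4 (0.49 log units; beyond the scatter)), so all three replacements at this position now lie above compound 1. Pairing chloro with methoxy does not separate compound 4 from the single-substituent groups: the steps (a 1.3-fold lower number from compound 3 to compound 4 (0.12 log units; within the scatter)) and (a 1.2-fold higher number from compound 2 to compound 4 (0.08 log units; within the scatter)) stay within the scatter. Nothing available explains these steps. On these data alone, whether a 4-tert-butylphenyl group, a longer alkyl chain or a 4-aminophenyl group would match compound 1 remains open.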